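This account rests on a few compounds, and the source may have more. Where it says the series, first, only, none or still open, it means among the compounds named here.

Compounds measured so far:
- Compound 1, `Fc1ccc(-c2ccc(Cn3nnc4ccccc43)cc2)c(F)c1`: 0.9 mL/min/g
- Compound 2, `Fc1cc(Cl)ccc1-c1ccc(Cn2nnc3c(Br)cccc32)cn1`: 0.1 mL/min/g
- Compound 3, `Brc1cccc2c1nnn2CC1CCCC1`: 7.9 mL/min/g

The three compounds were all tested in an ADME assay on microsomes from liver (Homo sapiens) for metabolic stability, tested at 2.5 uM; on this read-out higher numbers stand for fast clearance and lower numbers for slow clearance. Compound 3 stands at the high end of the three numbers: its value is beyond the scatter against both others, with compound 1 the nearer of the two and compound 2 the furthest away. The core of compound 3 carries a bromine and a cyclopentyl bound through a saturated chain carbon to an aromatic nitrogen.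

Compound 4, `CC(C)Cn1nnc2c(Br)cccc21`, has not yet been measured in this assay. It differs from compound 3 in a single place: isopropyl in place of cyclopentyl on a saturated chain carbon bound to an aromatic nitrogen. Cyclopentyl leaves, isopropyl enters, on the saturated chain carbon bound to the aromatic nitrogen; nothing else in the structure moves.

Within the data shown here, no measured pair in this set shares this change, so there is no direct step to lean on. Because compound 3 gives 7.9 mL/min/g, the expectation for compound 4 is a small downward step, a 1.6-fold lower number from compound 3 to compound 4 (0.20 log units; within the scatter), of a size that may still sit within the scatter. Compound 4 is therefore estimated at 5 mL/min/g, with a range from 2 mL/min/g to 12 mL/min/g.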

Compound 4, intrinsic clearance in a liver preparation (reported as CLH), per the amount of preparation that the assay uses: 4.2 mL/min/g
The estimate for compound 4 lay 1.2-fold (0.08 log units) above the measured number, and the stated range covers the measured number.
By their numbers in this assay, from the lowest: compound 2; then compound 1; then compounds 4 and 3 (each within the scatter of the next).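

In this assay, among these compounds, the exchange of cyclopentyl for isopropyl on a saturated chain carbon bound to an aromatic nitrogen gives a 1.9-fold lower number from compound 3 to compound 4 (0.27 log units; within the scatter), and this is the first step in the set that changes one place only. At this position, then, going from a group of 5 heavy atoms with a five-membered ring to one of 3 heavy atoms with no ring does not move the read-out beyond the usual scatter, so the two groups cannot be told apart here, and both compounds keep the same bromine-bearing core. No measurement at hand accounts for this, and the finding stands as an observation on this one pair alone.

Going by these compounds, what remains open is whether this tolerance holds for groups of another kind at the same place, such as a longer chain, a phenyl ring, an amine or a carboxylic acid, since cyclopentyl and isopropyl are both built of carbon only. On these data alone, it is also open whether the same exchange would read alike on a core carrying chlorine or hydrogen in place of the bromine.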